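A few compounds are considered here, and "the series" means these few. Any claim that something is new, unique, unknown or untested is made for them only; others in the source may bear on it.

Measured so far:
- compound 1 `COCCNC(=O)CCNc1ncc2c(Br)nn(-c3ccc4ncccc4c3)c2n1`: > 1000 nM
- compound 2 `COCCNC(=O)[C@H]1C[C@H](Nc2ncc3c(Br)nn(-c4ccc5ncccc5c4)c3n2)C1`: 40 nM

Compound 1 in an assay on isolated protein for inhibition of eIF-2-alpha kinase GCN2 (Homo sapiens) (a higher number here means a weaker inhibitor, a lower number a stronger inhibitor), gives only a limit, > 1000 nM, not a number; this is the limit of > 1000 nM in this assay, at which 1 of the 2 values shown sits. Compound 2 in this assay gives 40 nM. Among the measured compounds shown here, the two compounds differ in more than one place, so no single step between them is counted; their values show only that compound 2 is a measurable inhibitor where compound 1 is not.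

Compound 3 `CNC(=O)[C@]1(C)CC[C@@H](Nc2ncc3c(Br)nn(-c4ccc5ncccc5c4)c3n2)C1` is not yet measured. It differs from compound 1 by a group of 10 heavy atoms (8 carbon, 1 nitrogen, 1 oxygen; one five-membered non-aromatic ring of carbon only) in place of a group of 9 heavy atoms (6 carbon, 1 nitrogen, 2 oxygen; no ring), on a nitrogen on an aromatic ring. For the measured compounds named here, no measured step covers this change. A step toward stronger inhibition, beyond the scatter, is expected from compound 1 to compound 3, because compound 2 gives 40 nM. The estimate for compound 3 in this assay is 80 nM, within 15 nM to 400 nM, a step of an at least 12-fold lower number from compound 1 to compound 3 (1.09 log units; beyond the scatter).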

Compound 3, half-maximal inhibitory concentration: 17 nM
Compound 3: the middle estimate sits 4.7-fold (0.67 log units) above what was measured; measured number inside the range.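

Among the compounds shown here, replacing the open 2-((2-methoxyethyl)carbamoyl)ethyl chain on the nitrogen on an aromatic ring with a group holding a five-membered non-aromatic ring of carbon only gives the first one-place comparison of the series in this assay, a step of an at least 58-fold lower number from compound 1 to compound 3 (1.76 log units; beyond the scatter). From the compounds shown here alone, the value of compound 1 is a limit and not a number, so the true size of this step stays unknown beyond the minimum printed: the limit of > 1000 nM in this assay, at which 1 of the 3 values shown sits. Both groups count 1 hydrogen-bond donor and carry no net charge, so the step comes without a change in those counts, while the entering group adds a ring and 2 defined stereocentres.

The change alters chain, ring and stereocentres at once, so the share of each in the step remains unseparated. Going by these compounds, how a carboxylic acid or an amine in place of the amide on that ring, or the opposite configuration at either stereocentre, would read in this assay also remains open.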